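This account rests on a few compounds, and the source may have more. Where it says the series, first, only, none or still open, it means among the compounds named here.

The compounds share a core in which a methyl-bearing piperidine is joined to a second piperidine whose nitrogen carries a sulfonyl group, and they differ in what sits on that sulfonyl sulfur. In a functional assay on DLD-1 cells (Homo sapiens) for antiproliferative activity, read by CellTiter-Glo, with a stated time of 72 h (on this read-out lower numbers stand for stronger inhibition and higher numbers for weaker inhibition), compound 3 `CC1CCN(C2CCN(S(=O)(=O)c3cnc(Cl)s3)CC2)CC1` gives 1800 nM. Among the numbers given this is the highest: compound 2 `Cc1cc(C)cc(-c2cccc(S(=O)(=O)N3CCC(N4CCC(C)CC4)CC3)c2)c1` gives 41 nM in this assay, a far lower number, though its sulfonyl substituent differs in more than one way. Compound 1 `CC1CCN(C2CCN(S(=O)(=O)c3sc(Cl)nc3C3CC3)CC2)CC1` gives only a limit of the assay, > 5000 nM, in this assay. For the measured compounds named here, the one measured step, an at least 2.7-fold lower number from compound 1 to compound 3 (0.44 log units; beyond the scatter), shows that stripping the cyclopropyl from the five-membered ring moves the number down by at least a modest amount, and it rests on the limit (the limit of > 5000 nM in this assay, at which 1 of the 3 values shown sits).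

Compound 4 `CC1CCN(C2CCN(S(=O)(=O)c3ccc(Cl)nc3)CC2)CC1` replaces the ring itself: 6-chloropyridin-3-yl in place of 2-chloro-1,3-thiazol-5-yl on a sulfonyl sulfur. Going by the values given here, no measured step swaps one aromatic ring for another at this position, so the single measured step offers no direct guide, and the low number of compound 2 comes with other differences. Among the compounds with values here, with no close precedent, the step is estimated as a 1.5-fold lower number from compound 3 to compound 4 (0.18 log units; within the scatter), lying within the scatter. Compound 4 is therefore expected to give about 1200 nM, within a range from 300 nM to 5000 nM.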

Compound 4, half-maximal inhibitory concentration: 3700 nM
Compound 4: middle estimate off by 3.1-fold (0.49 log units), on the low side; measured number inside the range.
By their numbers in this assay, from the lowest: compound 2; then compound 3; then compound 4. At a limit, above all of these: compound 1.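

For the compounds shown here, this is the first measured change of the aromatic ring itself on the sulfonyl sulfur, rather than of a group carried by that ring. In this assay, putting 6-chloropyridin-3-yl in place of 2-chloro-1,3-thiazol-5-yl gives a 2.1-fold higher number from compound 3 to compound 4 (0.31 log units; beyond the scatter), so the number moves in the direction of weaker inhibition. The rest of the molecule stays the same and a chlorine is present on both rings, so the read-out at this position depends on the identity of the ring and not only on the groups attached to it, although this step is only modest.

The compounds shown leave open what would happen if the chlorine on either ring gave way to an amine or a methoxy group, and no single change connects compound 2 to the others, so the origin of its low number cannot be traced here. The value of compound 1, > 5000 nM, is a limit, so the full size of its step remains unknown: the limit of > 5000 nM in this assay, at which 1 of the 4 values shown sits.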